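Ethyl Ester Analogue of Compound 3: Expected Cytotoxicity

A few compounds are considered here, and "the series" means these few. Any claim that something is new, unique, unknown or untested is made for them only; others in the source may bear on it.

Of the compounds shown here, three with a shared core have been tested in an ADME assay on CCRF-CEM cells (Homo sapiens) for cytotoxicity; on this read-out lower numbers stand for higher toxicity in this test and higher numbers for lower toxicity in this test. Compound 1 `O=C(NCCO)c1cnc2ccccc2c1Cl` gives > 100 uM, which is a limit of the test and not a number. Compound 2 `COC(=O)[C@H](CSC)NC(=O)c1cnc2ccccc2c1Cl` gives 68.4 uM. Compound 3 `COC(=O)[C@H](CO)NC(=O)c1cnc2ccccc2c1Cl` gives > 100 uM, again a limit rather than a measured number. So compound 3 stands at the limit, as does compound 1, which is what the limit of > 100 uM in this assay, at which 2 of the 3 values shown sit, describes. The step that the two limits leave unreadable from compound 1 to compound 3 cannot be sized, while the step of an at least 1.4-fold higher number from compound 2 to compound 3 (0.16 log units; that floor lies within the scatter) is readable only as a floor. Compound 4 `CCOC(=O)[C@H](CO)NC(=O)c1cnc2ccccc2c1Cl` differs from compound 3 by methyl in place of hydrogen on a saturated chain carbon bound to an oxygen next to a carbonyl group. Within the data shown here, no measured step touches this ester group, so the measured steps give no direct guide, and both steps into compound 3 end at the limit. Compound 4 is therefore expected to sit close to that limit, with an estimated step of a number no higher from compound 3 to compound 4 (the limit leaves the size open). The estimate for compound 4 in this assay is 100 uM, in a range from 40 uM to 300 uM.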

Compound 4, half-maximal toxic concentration: > 100 uM
Compound 4 gave a limit, no number; the forecaster's own chance of this, stated with the estimate: 65%; the middle value sits exactly at the limit.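

Compound 4, like compound 1 and compound 3, gives a limit and not a number, so no step among these three can be read: the limit of > 100 uM in this assay, at which 3 of the 4 values shown sit. As far as these compounds go, whether ethoxycarbonyl in place of methoxycarbonyl changes the result in this assay at all remains open.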